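The source may report more compounds than this note shows. Statements on the series, on what has been measured and on what is new or still open speak of the compounds shown alone.

Measured compounds:
compound 1 `Cn1ncc(Cl)c1-c1cc(C(=O)N[C@@H]2CN[C@H](CCN3CCCCC3)C[C@H]2c2ccc(Cl)c(Cl)c2)oc1Cl` with 5.65 nM in an assay for inhibition of RAC-alpha serine/threonine-protein kinase (Homo sapiens), read by HTRF, with a stated time of 1 h; on this read-out higher numbers stand for weaker inhibition and lower numbers for stronger inhibition; compound 2 `C=CC[C@@H]1C[C@@H](c2ccc(Cl)c(Cl)c2)[C@H](NC(=O)c2cc(-c3c(Cl)cnn3C)c(Cl)o2)CN1` with 12.4 nM in this assay; compound 3 `CN(C)CC[C@@H]1C[C@@H](c2ccc(Cl)c(Cl)c2)[C@H](NC(=O)c2cc(-c3c(Cl)cnn3C)c(Cl)o2)CN1` with 3.4 nM in this assay.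

Compound 3 gives the lowest number of the three, yet its gap to compound 1 lies within the scatter (a 1.7-fold lower number from compound 1 to compound 3 (0.22 log units; within the scatter)), while its gap to compound 2 is a modest one beyond it (a 3.6-fold lower number from compound 2 to compound 3 (0.56 log units; beyond the scatter)). Compound 4 `Cn1ncc(Cl)c1-c1cc(C(=O)N[C@@H]2CN[C@H](CC(=O)NCC(O)CO)C[C@H]2c2ccc(Cl)c(Cl)c2)oc1Cl` differs from compound 3 by (2,3-dihydroxypropyl)carbamoyl in place of (dimethylamino)methyl on a saturated chain carbon bound to a saturated ring carbon. Within the data shown here, of the measured steps, only the one from compound 2 to compound 3 exchanges a group at this place, and it gave a modest change; the step from compound 1 to compound 3 was within the scatter. Compound 4 is therefore expected to show a modest rise in number, a 5.9-fold higher number from compound 3 to compound 4 (0.77 log units; beyond the scatter), estimated at 20 nM with a range of 6 nM to 70 nM.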

Compound 4, half-maximal inhibitory concentration: 3.13 nM
Estimate against measurement, compound 4: 6.4-fold (0.81 log units) above; the whole stated range lies above it.
By their numbers in this assay, from the lowest: compounds 4, 3 and 1 (each within the scatter of the next); then compound 2.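

In this assay, the place on a saturated chain carbon bound to a saturated ring carbon takes (2,3-dihydroxypropyl)carbamoyl with no change beyond the scatter against either (dimethylamino)methyl (a 1.1-fold lower number from compound 3 to compound 4 (0.04 log units; within the scatter)) or (piperidin-1-yl)methyl (a 1.8-fold lower number from compound 1 to compound 4 (0.26 log units; within the scatter)). An amine at the end of this chain is therefore not needed among these compounds, and only vinyl stands apart (a 4.0-fold lower number from compound 2 to compound 4 (0.60 log units; beyond the scatter)). Nothing available accounts for this result. As far as these compounds go, whether a carboxylic acid, a single hydroxyl or a longer chain would fit here remains open.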